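A few compounds are considered here, and "the series" means these few. Any claim that something is new, unique, unknown or untested is made for them only; others in the source may bear on it.

Measured compounds:
compound 1, `CC(C)[C@H]1CC[C@@]2(CO2)[C@H]2C(=O)OCC(C(=O)OCc3ccc(-c4ccccc4)o3)=C[C@H]12`: in a functional assay on A549 cells (Homo sapiens) for inhibition, with a stated time of 72 h (on this read-out higher numbers stand for weaker inhibition and lower numbers for stronger inhibition), compound 1 gives 350 nM
compound 2, `CC(C)[C@H]1CC[C@@]2(CO2)[C@H]2C(=O)OCC(C(=O)O)=C[C@H]12`: in this assay compound 2 gives 458 nM

Compound 2 carries the highest of the two numbers, yet its nearest neighbour is compound 1, whose value is within the scatter of it, so the two cannot be ordered on these data. Compound 3, `COC(=O)C1=C[C@@H]2[C@@H](C(C)C)CC[C@@]3(CO3)[C@H]2C(=O)OC1`, remains to be measured. It differs from compound 2 in one place, (methyl in place of hydrogen on an oxygen next to a carbonyl group); cut one bond further out, the change reads carboxy to methoxycarbonyl. Within the data shown here, no step between two measured compounds is available, so nothing measured speaks directly to what this change does. Compound 1 and compound 2 differ at the same oxygen by a much larger exchange and still sit within the scatter of each other, which gives no ground to expect a large move here. The step in this assay from compound 2 to compound 3 is therefore expected to be small, if anything toward a lower number, and most likely within the scatter: a 1.1-fold lower number from compound 2 to compound 3 (0.06 log units; within the scatter). Compound 3 is estimated at 400 nM, with a range from 150 nM to 1100 nM.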

Compound 3, half-maximal inhibitory concentration: 450 nM
Beside the measured number, compound 3's estimate is 1.1-fold (0.05 log units) below it, and the stated range covers the measured number.
By their numbers in this assay, from the lowest: compounds 1, 3 and 2 (each within the scatter of the next).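

In this assay, the change from carboxy to methoxycarbonyl now has a direct reading at this oxygen: a 1.0-fold lower number from compound 2 to compound 3 (0.01 log units; within the scatter), so the two compounds cannot be told apart on these data. The hydrogen on this oxygen is therefore not needed for a value of this size in this assay, since compound 3, which has a methyl there, gives 450 nM. Together with the much larger ester of compound 1, which also lies within the scatter of compound 2, this shows that this oxygen accepts both a small and a large group on the carboxy carbonyl without a step that can be read, although no measurement at hand bears on why this is so.

From the compounds shown here alone, it remains open whether replacing the oxygen itself, as in a primary amide or a hydroxymethyl group, or placing an amine on a longer chain at the ester oxygen, would stay within the scatter of compound 2. Going by these compounds, all three compounds keep the shared core unchanged, so what any part of that core contributes in this assay also remains open.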